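Adding chloro to compound 2

This account rests on a few compounds, and the source may have more. Where it says the series, first, only, none or still open, it means among the compounds named here.

In a functional assay on P388 cells (Mus musculus) for antiproliferative activity, read by colorimetric assay and MTT assay (on this read-out higher numbers stand for weaker inhibition and lower numbers for stronger inhibition), compound 2 (`Nc1ccc(S(=O)(=O)Nc2cccc3cc[nH]c23)cc1`) gives 14 ug/mL as the higher of two numbers, while compound 1 (`N#Cc1ccc(S(=O)(=O)Nc2cccc3c(Cl)c[nH]c23)cc1`) gives 1.4 ug/mL as the lower, a gap beyond the scatter. Compound 3 (`Nc1ccc(S(=O)(=O)Nc2cccc3c(Cl)c[nH]c23)cc1`) comes from compound 2 through chloro in place of hydrogen on an aromatic carbon with chloro in place of hydrogen on an aromatic carbon. Among the compounds with values here, no measured pair isolates this change, so the expectation leans on compound 1 at 1.4 ug/mL alone. An estimated 4.7-fold lower number from compound 2 to compound 3 (0.67 log units; beyond the scatter) is expected toward a lower number in this assay and beyond the scatter. For compound 3 the estimate is 3 ug/mL with 0.8 ug/mL to 10 ug/mL as the expected range.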

Compound 3, half-maximal inhibitory concentration: 0.81 ug/mL
For compound 3 the middle estimate is 3.7-fold (0.57 log units) above the measured one; measured number inside the range.
By their numbers in this assay, from the lowest: compounds 3 and 1 (each within the scatter of the next); then compound 2.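

In this assay, chloro in place of hydrogen on an aromatic carbon of the five-membered aromatic ring, two ring bonds from the ring nitrogen, now stands as an isolated change, with a large step: a 17-fold lower number from compound 2 to compound 3 (1.24 log units; beyond the scatter). With chloro present, amino in place of cyano gives a 1.7-fold lower number from compound 1 to compound 3 (0.24 log units; within the scatter), so this read-out does not separate the two groups. Nothing on hand bears on what lies behind the chloro step. From the compounds shown here alone, whether bromo or methyl at this position would match chloro stays open. So does the effect of cyano on the core without chloro.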